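Positional isomers of a sulfonamide hydrazide series

This account rests on a few compounds, and the source may have more. Where it says the series, first, only, none or still open, it means among the compounds named here.

Measured in a functional assay on A549 cells (Homo sapiens) for antiproliferative activity, read by MTT assay, with a stated time of 24 h; a lower number here means a stronger inhibitor, a higher number a weaker inhibitor:
compound 1, `Cc1ccccc1NNC(=O)c1ccc(NS(=O)(=O)c2cnc(O)nc2O)cc1`, gives 14500 nM;
compound 2, `Cc1cccc(NNC(=O)c2ccc(NS(=O)(=O)c3cnc(O)nc3O)cc2)c1`, gives > 20000 nM;
compound 3, `Cc1ccccc1NNC(=O)c1cccc(NS(=O)(=O)c2cnc(O)nc2O)c1`, gives 14200 nM.

The value for compound 2 is a limit of this assay, not a number. In this assay compound 1 and compound 3 sit within the usual scatter of each other, so no order can be read between them. The difference between the core of compound 1 and the core of compound 3 is not broken down here.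

From compound 1 to compound 2 one change is made, (3-methylphenyl in place of 2-methylphenyl on an amine nitrogen), and it gave an at least 1.3-fold higher number from compound 1 to compound 2 (0.13 log units; that floor lies within the scatter). Not yet measured is compound 4, `Cc1cccc(NNC(=O)c2cccc(NS(=O)(=O)c3cnc(O)nc3O)c2)c1`, which carries the same change against compound 3: 3-methylphenyl in place of 2-methylphenyl on an amine nitrogen.

In this assay compound 4 is expected to give about 22000 nM, with a likely range from 12000 nM to 45000 nM. This expectation for compound 4 rests on the earlier step of an at least 1.3-fold higher number from compound 1 to compound 2 (0.13 log units; that floor lies within the scatter) and on the limit (the limit of > 20000 nM in this assay, at which 1 of the 3 values shown sits), which suggest a higher number and a fair chance of another limit. The estimated step is a 1.5-fold higher number from compound 3 to compound 4 (0.19 log units; within the scatter).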

Compound 4, half-maximal inhibitory concentration: > 20000 nM
Compound 4: no number, only a limit; the forecaster's own chance of this, stated with the estimate: 55%; the middle value is on the limit's open side.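

In this assay compound 4 gives > 20000 nM, which is a limit of the assay and not a number. Putting 3-methylphenyl in place of 2-methylphenyl on the amine nitrogen gave an at least 1.4-fold higher number from compound 3 to compound 4 (0.14 log units; that floor lies within the scatter), so on this second core the step again has only a floor, and that floor lies within the scatter. The two cores therefore show no conflict, but this does not show that the change has the same size on both, or that it has a real effect on either core: the same change on two cores in this assay, an at least 1.3-fold higher number (0.13 log units; that floor lies within the scatter) from compound 1 to compound 2 and an at least 1.4-fold higher number (0.14 log units; that floor lies within the scatter) from compound 3 to compound 4; the limit leaves it open whether they differ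

As far as these compounds go, the true size of each step stays unknown while both compounds with the 3-methylphenyl group sit at a limit: the limit of > 20000 nM in this assay, at which 2 of the 4 values shown sit. Also open is how either core would respond if a chlorine atom or a methoxy group took the place of the methyl group on the phenyl ring.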